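Thiosemicarbazide amidines: ring size at the thiocarbonyl carbon

The compounds below may be only part of what the source reports. "The series", "measured", "known", "first", "only" and "open" are said of these compounds alone.

Compound 1 `Cc1cccc(/C(N)=N/NC(=S)N2CCCCC2)n1` and compound 2 `Cc1cccc(/C(N)=N/NC(=S)N2CCCC2)n1` share one core; compound 3 `Cc1ccnc(/C(N)=N/NC(=S)N2CCCCC2)c1` and the unmeasured compound 4 `Cc1ccnc(/C(N)=N/NC(=S)N2CCCC2)c1` share another. How the two cores differ is not broken down here.

In a functional assay on MCF7 cells (Homo sapiens) for cytotoxicity, read by MTT assay, with a stated time of 72 h, tested at 30 uM (on this read-out lower numbers stand for less inhibition of growth and higher numbers for more inhibition of growth at the one concentration tested), compound 1 gives 43% and compound 2 gives 40.1%. The step from compound 1 to compound 2 is a number 2.9 percentage points lower from compound 1 to compound 2 (within the scatter), the change being (pyrrolidin-1-yl in place of piperidin-1-yl on a thiocarbonyl carbon).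

In this assay compound 3 gives 61.7%, the highest of the three values, beyond the scatter from compound 1 and from compound 2.

Compound 4 carries the same kind of change on the core of compound 3: pyrrolidin-1-yl in place of piperidin-1-yl on a thiocarbonyl carbon. The two place descriptions agree word for word. Among the compounds with values here, the one measured instance of this change, from compound 1 to compound 2, stayed within the scatter, so the step from compound 3 to compound 4 in this assay is expected to be about as small, a number 2.7 percentage points lower from compound 3 to compound 4 (within the scatter). This rests on a single pair and on compound 3 standing at 61.7%.

Compound 4 is estimated at 59% in this assay, with a likely range from 47% to 70%.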

Compound 4, percent growth inhibition at one concentration: 82.2%
Estimate against measurement, compound 4: 23.2 percentage points below, outside the stated range (above it).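

Pyrrolidin-1-yl in place of piperidin-1-yl on a thiocarbonyl carbon gives a number 20.5 percentage points higher from compound 3 to compound 4 (beyond the scatter), so in this assay the outcome of this change depends on the core that carries it, and the two instances differ: the same change on two cores in this assay, a number 2.9 percentage points lower (within the scatter) from compound 1 to compound 2 and a number 20.5 percentage points higher (beyond the scatter) from compound 3 to compound 4, 23.4 percentage points apart, beyond the scatter of two such steps

A step read on one of these cores therefore cannot be carried over to the other as a working rule, and the near-zero step on the core of compound 1 says little about the core of compound 3. Within the data shown here, the comparison rests on only two matched pairs, each read at one concentration, so it gives no reason for the difference and no rule for any further core.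

Open, going by these compounds, is how morpholin-4-yl, azepan-1-yl or a dimethylamino group on the thiocarbonyl carbon would behave on each core, and whether the two cores would still part in the same way. Also open, on these data alone, is whether the gap between the two steps would persist in a full concentration-response series.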